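Shifting the methoxy group: from compound 2 to compound 3

This account rests on a few compounds, and the source may have more. Where it says the series, first, only, none or still open, it means among the compounds named here.

In a functional assay on MCF7 cells (Homo sapiens) for cytotoxicity, read by MTT assay, with a stated time of 72 h (on this read-out higher numbers stand for weaker inhibition and lower numbers for stronger inhibition), compound 1 `O=C1C(=Cc2ccc(Cl)cc2)C(=O)N(c2ccc(Cl)cc2)N1c1ccc(Cl)cc1` gives 28500 nM. Compound 2 `COc1ccc(C=C2C(=O)N(c3ccc(Cl)cc3)N(c3ccc(Cl)cc3)C2=O)cc1` gives > 128000 nM, which is a limit of the assay and not a number. Compound 2 therefore has no exact place on the scale. Compound 3 `COc1cccc(C=C2C(=O)N(c3ccc(Cl)cc3)N(c3ccc(Cl)cc3)C2=O)c1` differs from compound 2 by 3-methoxyphenyl in place of 4-methoxyphenyl on a double-bonded chain carbon bound to a double-bonded ring carbon, with 3-methoxyphenyl in place of 4-methoxyphenyl on a double-bonded chain carbon bound to a double-bonded ring carbon. Going by the values given here, one measured step bears on this, and only indirectly: an at least 4.4-fold higher number from compound 1 to compound 2 (0.65 log units; beyond the scatter), for methoxy in place of chloro on an aromatic carbon. Among the compounds with values here, no measured step moves a methoxy group, so the size of this change remains open. Compound 3 keeps the methoxy group and is expected to stay at the weak end of this assay. The expected step is small and rough, an at least 1.2-fold lower number from compound 2 to compound 3 (0.10 log units; that floor lies within the scatter), since it is set against a limit. In this assay the estimate for compound 3 is 100000 nM, with an expected range of 35000 nM to 200000 nM.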

Compound 3, half-maximal inhibitory concentration: 18100 nM
Compound 3: middle estimate off by 5.5-fold (0.74 log units), on the high side, outside the stated range (below it).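

In this assay, the place of the methoxy group on the phenyl ring matters: 3-methoxyphenyl in place of 4-methoxyphenyl on a double-bonded chain carbon bound to a double-bonded ring carbon gives an at least 7.0-fold lower number from compound 2 to compound 3 (0.84 log units; beyond the scatter), so a methoxy group at this place does not by itself hold the series at the weak end. Against the chloro compound the result is a 1.6-fold lower number from compound 1 to compound 3 (0.20 log units; within the scatter), so 3-methoxyphenyl and 4-chlorophenyl cannot be told apart here. The true size of the methoxy shift stays unknown, and only a floor can be given, because compound 2 stands at a limit of the assay and not at a number: the limit of > 128000 nM in this assay, at which 1 of the 3 values shown sits.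

Open, as far as these compounds go, is whether 3-chlorophenyl at this place would track 3-methoxyphenyl or 4-chlorophenyl. Also open, from the compounds shown here alone, is how a hydroxy group or an amine on this phenyl ring would read.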